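Three limits, a fourth analogue awaiting its number

A few compounds are considered here, and "the series" means these few. Any claim that something is new, unique, unknown or untested is made for them only; others in the source may bear on it.

Compound 1 `COc1cccc(/C=C/C(=O)c2sc(Nc3cccc(C)c3)nc2C)c1`: in a functional assay on PC-3 cells (Homo sapiens) for cytotoxicity, read by MTT assay (a lower number here means a stronger inhibitor, a higher number a weaker inhibitor), compound 1 gives > 25000 nM, a limit of the assay.
Compound 2 `Cc1nc(Nc2cccc(Cl)c2)sc1C(=O)/C=C/c1ccccc1`: in this assay compound 2 gives > 25000 nM, a limit of the assay.
Compound 3 `Cc1nc(Nc2cccc(Cl)c2)sc1C(=O)/C=C/c1ccc(Cl)cc1`: in this assay compound 3 gives > 25000 nM, a limit of the assay.

Compound 3 stands at a limit, and the two other values stand at the same limit, so no order among the three can be read. Within the data shown here, the one single-point step that has been measured, a step that the two limits leave unreadable from compound 2 to compound 3, is unreadable for the same reason, because of the limit of > 25000 nM in this assay, at which 3 of the 3 values shown sit.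

Compound 4 `COc1cccc(/C=C/C(=O)c2sc(Nc3cccc(Cl)c3)nc2C)c1` differs from compound 3 by 3-methoxyphenyl in place of 4-chlorophenyl on a double-bonded chain carbon bound to a double-bonded chain carbon. Among the measured compounds shown here, the only measured step bears on it indirectly and gives no size. For the measured compounds named here, compound 1 carries the same 3-methoxyphenyl group as compound 4 and sits at the limit, which is the sole guide. No step beyond the scatter in this assay is expected in either direction. Compound 4 is therefore expected to give 40000 nM, in the range 15000 nM to 120000 nM. The expected step is a step that the limit leaves unreadable from compound 3 to compound 4, most likely reported again only as a limit.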

Compound 4, half-maximal inhibitory concentration: > 25000 nM
Compound 4: only a limit was reported; the forecaster's own chance of this, stated with the estimate: 85%; the middle value is on the limit's open side.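

Among these compounds, no step from compound 1, compound 2 or compound 3 to compound 4 can be read, because all four compounds sit at one shared limit: the limit of > 25000 nM in this assay, at which 4 of the 4 values shown sit. The compounds shown leave open the actual potency of each of the four, and whether any of these group changes alters it.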